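This account rests on a few compounds, and the source may have more. Where it says the series, first, only, none or still open, it means among the compounds named here.

Compound 1, `CCCCCCCCCc1cc2cn(COCCO)c(O)nc-2n1`, and compound 2, `CCCCCCCCCCCc1cc2cn(COCCO)c(=O)nc2o1`, share a core that differs only in its saturation, while compound 3, `CCCCCCCCCc1cc2cn(COCCO)c(=O)nc2o1`, is not yet measured. In a functional assay on HEL cells (Homo sapiens), read by microscopy (a lower number here means that less compound is tolerated, a higher number that more compound is tolerated), compound 1 reports a limit of the assay, > 80000 nM. In this assay, going by the values given here, compound 2 gives 80000 nM, the single number here. Compound 1 contributes the other value, which is the limit (the limit of > 80000 nM in this assay, at which 1 of the 2 values shown sits). The change from compound 2 to compound 3 is hydrogen in place of ethyl on a saturated chain carbon, nine bonds along the chain from an aromatic carbon. Among the compounds with values here, with no measured step to lean on, the expected step from compound 2 to compound 3 is no change at the digits printed from compound 2 to compound 3 (within the scatter), small, toward more tolerated. Compound 3 is thus estimated at 80000 nM, between 40000 nM and 160000 nM.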

Compound 3, minimum cytotoxic concentration: >= 16000 nM
Compound 3: only a limit was reported; the forecaster's own chance of this, stated with the estimate: 50%; the middle value lies beyond the limit too.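

Going by these compounds alone, compound 3 is reported only as a limit of the assay, and no step from compound 2 to compound 3 can be read. The compounds shown leave open whether hydrogen in place of ethyl on that saturated chain carbon changes how much compound is tolerated.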